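A few compounds are considered here, and "the series" means these few. Any claim that something is new, unique, unknown or untested is made for them only; others in the source may bear on it.

Measured in a functional assay on KB cells (Homo sapiens) for inhibition, with a stated time of 72 h; on this read-out lower numbers stand for stronger inhibition and higher numbers for weaker inhibition:
- Compound 1 `CC(=O)O[C@@]12CO[C@@H]1C[C@H](O)[C@@](C)(C(=O)[C@H](O)C1=C(C)C3C[C@@](O)([C@H](C)OC(=O)CC/C=C\CCC(=O)N[C@@H](c4ccccc4)[C@@H](O)C(=O)O3)C1(C)C)C2`: > 100000 nM (a limit of the assay)
- Compound 2 `C=CCCCC(=O)N[C@@H](c1ccccc1)[C@@H](O)C(=O)OC1C[C@@](O)([C@H](C)OC(=O)CCCC=C)C(C)(C)C([C@@H](O)C(=O)[C@@]2(C)C[C@]3(OC(C)=O)CO[C@@H]3C[C@@H]2O)=C1C`: 10 nM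
- Compound 3 `CC(=O)O[C@@]12CO[C@@H]1C[C@H](O)[C@@](C)(C(=O)[C@H](O)C1=C(C)[C@@H]3C[C@@](O)([C@H](C)OC(=O)CCCC/C=C/CCCCC(=O)N[C@@H](c4ccccc4)[C@@H](O)C(=O)O3)C1(C)C)C2`: 14000 nM

The value for compound 1 is a limit and not a number. Compound 2 gives 10 nM and compound 3 gives 14000 nM, the higher of the two numbers, with a gap well beyond the scatter. Compound 4 `CC(=O)O[C@@]12CO[C@@H]1C[C@H](O)[C@@](C)(C(=O)[C@H](O)C1=C(C)C3C[C@@](O)([C@H](C)OC(=O)CCCC/C=C/CCCCC(=O)N[C@@H](c4ccccc4)[C@@H](O)C(=O)O3)C1(C)C)C2` has the same atoms and bonds as compound 3: the two compounds have the same atoms and bonds; at least one stereo element is drawn with a configuration in one of them and without one in the other: 1 of 11 stereo elements differ; a stereocentre at a saturated ring carbon is drawn S in compound 3 and without a configuration in compound 4. Among the measured compounds shown here, no measured pair isolates such a difference, so the expectation rests on compound 3 at 14000 nM. In this assay the estimated 1.1-fold higher number from compound 3 to compound 4 (0.03 log units; within the scatter) is expected to stay within the scatter, with no clear direction. Compound 4 is expected at 15000 nM, with an estimated range of 5000 nM to 60000 nM.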

Compound 4, half-maximal inhibitory concentration: 8000 nM
Beside the measured number, compound 4's estimate is 1.9-fold (0.27 log units) above it, and the stated range covers the measured number.
By their numbers in this assay, from the lowest: compound 2; then compounds 4 and 3 (each within the scatter of the next). At a limit, above all of these: compound 1.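

In this assay, the change at this saturated ring carbon gives a 1.8-fold lower number from compound 3 to compound 4 (0.24 log units; within the scatter), so this is the first pair shown that differs in one place, and dropping the drawn configuration does not separate the two compounds on this read-out. The pair does not compare two defined configurations, and its reading has this limit: the fact that one of compounds 3 and 4 is drawn with a defined configuration and the other without, at the place where they differ

On these data alone, whether the opposite configuration, drawn as defined at this carbon, would read differently stays open. So does whether a longer chain in place of the one shared by compound 3 and compound 4 would change the number.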